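A few compounds are considered here, and "the series" means these few. Any claim that something is new, unique, unknown or untested is made for them only; others in the source may bear on it.

Measured compounds in an ADME assay on cells for inhibition of Amine oxidase [flavin-containing] A (Homo sapiens), read by spectrophotometry; on this read-out lower numbers stand for stronger inhibition and higher numbers for weaker inhibition:
- compound 1 `S=C(Nc1ccccc1)Nc1ccc2[nH]ccc2c1` gives > 30000 nM, which is a limit of the assay and not a number.
- compound 2 `Oc1ccccc1NC(=S)Nc1ccc2[nH]ccc2c1` gives 39000 nM.

Compound 1 stands only at a limit in this assay, so its place relative to compound 2 cannot be read. Going by the values given here, the one measured step, a step that the limit leaves unreadable from compound 1 to compound 2, has no readable size because of the limit of > 30000 nM in this assay, at which 1 of the 2 values shown sits. Compound 2 sits at the weak end of the read-out.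

Compound 3 `COc1ccc(NC(=S)Nc2ccc3[nH]ccc3c2)cc1` differs from compound 1 by methoxy in place of hydrogen on an aromatic carbon. Among the compounds with values here, no measured step concerns a methoxy, and the single step that is measured, a hydroxy in place of hydrogen, cannot be sized. Within the data shown here, the only guidance is that both measured compounds sit at the weak end, and a small neutral group on the same ring gives no ground to expect a move beyond the scatter in either direction. Compound 3 is therefore expected to remain weak in this assay, at roughly 40000 nM (range 15000 nM to 120000 nM). The implied step that the limit leaves unreadable from compound 1 to compound 3 is an expectation only, since compound 1 offers no readable starting number, and a limit rather than a value is likely for compound 3.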

Compound 3, half-maximal inhibitory concentration: 36000 nM
The estimate for compound 3 lay 1.1-fold (0.05 log units) above the measured number, and the stated range covers the measured number.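

The step from compound 1 to compound 3 cannot be read, because compound 1 stands only at a limit and not at a number: the limit of > 30000 nM in this assay, at which 1 of the 3 values shown sits. The compounds shown leave open whether methoxy or hydroxy in place of hydrogen on an aromatic carbon changes inhibition at all relative to compound 1.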